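The compounds below may be only part of what the source reports. "The series", "measured", "known", "first", "only" and "open" are said of these compounds alone.

In an assay on isolated protein for inhibition of lysosomal alpha-glucosidase (Rattus norvegicus), read by colorimetric assay (on this read-out higher numbers stand for weaker inhibition and lower numbers for stronger inhibition), compound 2 `C[C@]1(CO)NC[C@@H](O)[C@@H]1O` gives 830 nM, the higher of the two numbers recorded so far, while compound 1 `CCCC[C@@]1(CO)NC[C@H](O)[C@H]1O` gives 220 nM in this assay, a gap beyond the usual scatter. Compound 3 `CCCC[C@]1(CO)NC[C@@H](O)[C@@H]1O` differs from compound 2 by a single change, (propyl in place of hydrogen on a saturated chain carbon bound to a saturated ring carbon), and has not yet been measured in this assay. Going by the values given here, with no measured pair showing this step, the expected step from compound 2 to compound 3 is a 2.8-fold lower number from compound 2 to compound 3 (0.44 log units; beyond the scatter), a modest move toward stronger inhibition. Compound 3 is accordingly estimated at 300 nM in this assay, within a range from 100 nM to 1000 nM.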

Compound 3, half-maximal inhibitory concentration: 16000 nM
The estimate for compound 3 lay 53-fold (1.73 log units) below the measured number, outside the stated range (above it).
By their numbers in this assay, from the lowest: compound 1; then compound 2; then compound 3.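

Propyl in place of hydrogen on a saturated chain carbon bound to a saturated ring carbon weakens inhibition in this assay, with a 19-fold higher number from compound 2 to compound 3 (1.29 log units; beyond the scatter). The chain therefore does not bring stronger inhibition in the configuration of compound 3, and the same atoms give a 73-fold higher number from compound 1 to compound 3 (1.86 log units; beyond the scatter). This large gap comes with configuration alone: the fact that compounds 1 and 3 differ only in the configuration as drawn

On these data alone, how an ethyl chain, a hexyl chain or a benzyl group would behave at this position, in either configuration, remains open.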